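Compound 3 to compound 4: a carbonyl substituent swap

The source may hold more compounds than are shown below. What is called first, only, known or untested is meant among the compounds shown, and "the series" means these compounds.

For the measured compounds named here, in a functional assay on HepG2 cells (Homo sapiens) for inhibition, read by sulforhodamine B assay, with a stated time of 3 days (a higher number here means a weaker inhibitor, a lower number a stronger inhibitor), three compounds have numbers so far. Compound 3 (`COc1ccc(C(=O)Nc2ccc3c(c2)/C(=C/Nc2cccc(N4CCN(C)CC4)c2)C(=O)N3)cc1`) gives 1780 nM and is the reference point for these notes. Compound 1 (`O=C1Nc2ccc(F)cc2/C1=C\C(=O)c1ccc[nH]1`) gives 3120 nM and sits within the scatter of compound 3. Compound 2 (`O=C1Nc2ccc(F)cc2/C1=C\C(=O)c1cccs1`) gives 8780 nM and is the only one of the three whose number stands beyond the scatter from compound 3, on the weaker side.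

Compound 4 (`CN1CCN(c2cccc(N/C=C3\C(=O)Nc4ccc(NC(=O)c5cccc(F)c5)cc43)c2)CC1`) is not yet measured. It differs from compound 3 in one place (3-fluorophenyl in place of 4-methoxyphenyl on a carbonyl carbon), with 3-fluorophenyl in place of 4-methoxyphenyl on a carbonyl carbon whose other neighbour is an amide-type nitrogen.

Going by the values given here, only one measured step bears on this change, and only loosely. That step, a 2.8-fold higher number from compound 1 to compound 2 (0.45 log units; beyond the scatter), is modest and also sits on a carbonyl carbon, with thiophen-2-yl in place of 1H-pyrrol-2-yl, but on a different core. Among the compounds with values here, no measured pair varies the group changed here, so no direction can be read from the data. A step within the scatter is therefore expected, with room for a modest shift either way. The estimated step is a 1.1-fold higher number from compound 3 to compound 4 (0.05 log units; within the scatter) and carries no firm direction. For compound 4 the estimated value is 2000 nM with an expected range (650 nM to 6000 nM).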

Compound 4, half-maximal inhibitory concentration: 6720 nM
Compound 4: the middle estimate sits 3.4-fold (0.53 log units) below what was measured; measured number outside the range, above it.
By their numbers in this assay, from the lowest: compounds 3 and 1 (each within the scatter of the next); then compounds 4 and 2 (each within the scatter of the next).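

In this assay the aryl group on the carbonyl carbon whose other neighbour is an amide-type nitrogen is not a silent position: 3-fluorophenyl in place of 4-methoxyphenyl gives a 3.8-fold higher number from compound 3 to compound 4 (0.58 log units; beyond the scatter) and so a weaker inhibitor. This is a first direction for this substituent, favouring 4-methoxyphenyl over 3-fluorophenyl in this one pair, which the thiophen-2-yl and 1H-pyrrol-2-yl pair on the core of compound 1 could not supply. Nothing at hand accounts for the step, which can only be recorded as a swap of a methoxy-bearing ring for a fluorine-bearing one, with one hydrogen-bond acceptor counted on the group that leaves and none on the group that enters.

The swap changes the substituent and its place on the ring together, so a single pair cannot separate the contribution of methoxy from that of fluorine or of where each sits. Also open, on these data alone, is how far the position extends beyond substituted phenyl groups, for example to a carboxylic acid or an aliphatic amine on the aryl ring, or to a plain unsubstituted phenyl.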